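Removing the methyl from the ring nitrogen of compound 3

A few compounds are considered here, and "the series" means these few. Any claim that something is new, unique, unknown or untested is made for them only; others in the source may bear on it.

Compound 1, `COc1cc(C(=O)O)ccc1Cc1cn(C)c2ccc(NC(=O)NC3CCCC3)cc12`, gives 1120 nM in an assay on lung parenchyma for displacement of a labelled ligand from cysteinyl leukotriene receptor 1 (Cavia porcellus); a lower number here means a stronger inhibitor, a higher number a weaker inhibitor. Compound 2, `CCCn1cc(Cc2ccc(C(=O)O)cc2OC)c2cc(NC(=O)OC3CCCC3)ccc21`, gives 58 nM in this assay. Compound 3, `COc1cc(C(=O)O)ccc1Cc1cn(C)c2ccc(NC(=O)OC3CCCC3)cc12`, gives 157 nM in this assay.

Compound 3 stands second highest of the three numbers, with compound 2 nearest below it and compound 1 furthest above it. Compound 4, `COc1cc(C(=O)O)ccc1Cc1c[nH]c2ccc(NC(=O)OC3CCCC3)cc12`, differs from compound 3 by hydrogen in place of methyl on an aromatic nitrogen. For the measured compounds named here, of the two measured steps, only the one from compound 2 to compound 3 bears on this change, since the step from compound 1 to compound 3 alters the carbonyl substituent instead. Shortening the chain on the aromatic nitrogen gave a 2.7-fold higher number from compound 2 to compound 3 (0.43 log units; beyond the scatter). Removing the remaining carbon from that nitrogen is therefore expected to move the number in the same direction, by a modest step beyond the scatter, though a larger shift cannot be ruled out. For compound 4 the expected step is a 2.2-fold higher number from compound 3 to compound 4 (0.35 log units; beyond the scatter). Compound 4 is estimated at 350 nM, within a range from 130 nM to 950 nM.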

Compound 4, inhibition constant: 236 nM
The estimate for compound 4 lay 1.5-fold (0.17 log units) above the measured number; low and high end bracket the measured number.
By their numbers in this assay, from the lowest: compound 2; then compounds 3 and 4 (each within the scatter of the next); then compound 1.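

In this assay, hydrogen in place of methyl on the aromatic nitrogen gave a 1.5-fold higher number from compound 3 to compound 4 (0.18 log units; within the scatter), so at this position these two groups cannot be told apart. Hydrogen in place of propyl gave a 4.1-fold higher number from compound 2 to compound 4 (0.61 log units; beyond the scatter), which shows that, among the three groups seen on this nitrogen, propyl alone stands clear of both others, while the step from methyl to hydrogen adds nothing that can be read beyond the scatter. No measurement at hand explains how this nitrogen substituent affects the number.

The compounds shown leave open whether a butyl group or a longer chain on this nitrogen would give a still lower number than propyl does. They also leave open whether hydrogen in place of methyl would give as small a step with the cyclopentylamino group of compound 1.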